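Chloro in place of hydrogen on compound 2

The source may report more compounds than this note shows. Statements on the series, on what has been measured and on what is new or still open speak of the compounds shown alone.

Going by the values given here, in a functional assay on MCF7 cells (Homo sapiens) for antiproliferative activity, read by MTT assay, with a stated time of 48 h (a lower number here means a stronger inhibitor, a higher number a weaker inhibitor), compound 2 (`O=C(/C=C/c1ccccc1)Nc1cc(-c2ccc(Br)cc2)[nH]n1`) gives 1120 nM and lies within the scatter of its only measured neighbour. That neighbour is compound 1 (`Cc1ccc(-c2cc(NC(=O)/C=C/c3ccc(Cl)cc3)n[nH]2)cc1`), which gives 1190 nM and differs from compound 2 in more than one place. Among the compounds with values here, the two values therefore do not separate the compounds, and no measured pair isolates a single structural change.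

Compound 3 (`O=C(/C=C/c1ccc(Cl)cc1)Nc1cc(-c2ccc(Br)cc2)[nH]n1`) follows from compound 2 through the change chloro in place of hydrogen on an aromatic carbon that puts chloro in place of hydrogen on an aromatic carbon, para to a large group, turning phenyl to 4-chlorophenyl. Within the data shown here, the only evidence on this group comes from compound 1, which already carries 4-chlorophenyl and still gives 1190 nM in the same range as compound 2. No step beyond the scatter is therefore expected in this assay and no direction can be argued from two values. The estimated 1.1-fold lower number from compound 2 to compound 3 (0.05 log units; within the scatter) is expected to stay within the scatter. Compound 3 is estimated at 1000 nM with an expected range of 450 nM to 2200 nM in this series.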

Compound 3, half-maximal inhibitory concentration: 770 nM
Estimate against measurement, compound 3: 1.3-fold (0.11 log units) above; measured number inside the range.
By their numbers in this assay, from the lowest: compounds 3, 2 and 1 (each within the scatter of the next).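

Going by these compounds alone, compound 2 and compound 3 form the first pair that isolates a single change, chloro in place of hydrogen on an aromatic carbon, para to a large group, and in this assay phenyl to 4-chlorophenyl gives only a small step (a 1.5-fold lower number from compound 2 to compound 3 (0.16 log units; within the scatter)). Compound 1 and compound 3 form a second single-change pair, this time at the other aromatic ring, and bromo in place of methyl on an aromatic carbon also stays small (a 1.5-fold lower number from compound 1 to compound 3 (0.19 log units; within the scatter)), so neither place has yet given a step that can be separated from assay noise. No further measurement bears on these two steps.

Going by these compounds, whether either place can produce a step beyond the scatter remains open, as chloro, bromo and methyl are the only substituents compared there, and an amine, a carboxylic acid or a longer alkyl chain at the same carbons could behave differently. The compounds shown also leave open how the series responds to changes at the amide hydrogen or the alkene linker, since all three compounds share them unchanged.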